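Swapping the ring nitrogen substituent of a thiazolidinone amide

A few compounds are considered here, and "the series" means these few. Any claim that something is new, unique, unknown or untested is made for them only; others in the source may bear on it.

Measured compounds:
- compound 1, `CC(C)(C)c1conc1N1C(=O)CSC1c1cccc(C(=O)NCCCCc2ccccc2)c1`: > 1000 nM
- compound 2, `CCOc1ccccc1N1C(=O)C(C)SC1c1cccc(C(=O)NCCCCc2ccccc2)c1`: 71.6 nM
- compound 3, `Cc1ccnc(N2C(=O)CS[C@H]2c2cccc(C(=O)NCCCCn3cccn3)c2)c1`: > 10000 nM

In a functional assay on HOS-TE85 cells (Homo sapiens) for inhibition, read by CCK-8 assay, with a stated time of 72 h (on this read-out lower numbers stand for stronger inhibition and higher numbers for weaker inhibition), compound 1 reaches only (the limit of > 1000 nM in this assay, at which 1 of the 3 values shown sits), a limit rather than a number. Compound 3 likewise sits at a limit, (the limit of > 10000 nM in this assay, at which 1 of the 3 values shown sits). For the measured compounds named here, compound 2 is the one compound here with a measured value. Compound 4, `O=C(NCCCCc1ccccc1)c1cccc(C2SCC(=O)N2c2ccc(C3CC3)cc2)c1`, has not yet been measured. It differs from compound 1 in one place: a group of 9 heavy atoms (9 carbon; one three-membered non-aromatic ring of carbon only, one six-membered aromatic ring of carbon only) in place of a group of 9 heavy atoms (7 carbon, 1 nitrogen, 1 oxygen; one five-membered aromatic ring with 2 hetero atoms), on an amide-type nitrogen in a ring. Going by the values given here, no measured pair shares exactly this change, so its effect cannot be read from the data. Compound 2, which also carries a six-membered carbon ring on that nitrogen, suggests a gain in this assay beyond the usual scatter. Compound 4 is therefore expected near 250 nM, between 40 nM and 2000 nM, a step of an at least 4.0-fold lower number from compound 1 to compound 4 (0.60 log units; beyond the scatter).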

Compound 4, half-maximal inhibitory concentration: 217 nM
Compound 4: middle estimate off by 1.2-fold (0.06 log units), on the high side, within the range that was stated.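

Placing 4-cyclopropylphenyl on the amide-type nitrogen in place of the five-membered aromatic ring gives the first direct one-place reading at this position: an at least 4.6-fold lower number from compound 1 to compound 4 (0.66 log units; beyond the scatter). The potency in this assay therefore depends on the group carried here, and with a ring of carbon only compound 4 gives 217 nM. Going by these compounds, the true size of the step is unknown, as compound 1 stands at a limit and not at a number: the limit of > 1000 nM in this assay, at which 1 of the 4 values shown sits.

On these data alone, how much of the gain belongs to the six-membered ring and how much to the cyclopropyl group remains open. A plain phenyl ring or a 4-aminophenyl group at this position could help to separate the two.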